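Methoxyphenyl in place of methylphenyl: a small expected step

The source may report more compounds than this note shows. Statements on the series, on what has been measured and on what is new or still open speak of the compounds shown alone.

Measured so far:
compound 1 `Nc1nc(NCc2ccccc2F)nc(-c2c(F)cccc2CO)n1` gives 4.22 in a functional assay on cells for positive allosteric modulation of G-protein coupled receptor 68 (Homo sapiens), read by a luciferase reporter and cAMP accumulation, with a stated time of 30 min, at pH 6.8 and pH 8.3, in the presence of a further agent that is not named here; a higher number here means a more potent compound, by a factor of ten per unit of this negative logarithm, a lower number a less potent compound
compound 2 `Cc1cccc(CNc2nc(N)nc(-c3c(F)cccc3CO)n2)c1` gives 4.44 in this assay

Within the data shown here, compound 2 holds the higher of the two numbers in this assay, but its only neighbour, compound 1, sits close: the step of a number 0.22 log units higher from compound 1 to compound 2 (within the scatter) is within the scatter, so the two compounds cannot be ordered on these data.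

Compound 3 `COc1ccccc1CNc1nc(N)nc(-c2c(F)cccc2CO)n1` has not yet been measured. It differs from compound 2 in one place: 2-methoxyphenyl in place of 3-methylphenyl on a saturated chain carbon bound to a nitrogen on an aromatic ring. Among the measured compounds shown here, the single measured step, from compound 1 to compound 2, swapped one aryl group for another at the same place and was small; it is the only guide available, and it does not cover a methoxy group. For the measured compounds named here, no measured step therefore bears directly on this change. On that basis compound 3 is expected to sit near compound 2, with a step of a number 0.04 log units lower from compound 2 to compound 3 (within the scatter) that stays within the scatter. The estimate for compound 3 in this assay is 4.4, with a range from 4 to 4.8.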

Compound 3, negative logarithm of the antagonist equilibrium constant: 4.11
The estimate for compound 3 lay 0.29 log units above the measured number; the range from low to high includes it.
By their numbers in this assay, from the lowest: compounds 3, 1 and 2 (each within the scatter of the next, the first and the last beyond it).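

Among these compounds, this is the first change at this place on a saturated chain carbon bound to a nitrogen on an aromatic ring that registers beyond the scatter: in this assay, 2-methoxyphenyl in place of 3-methylphenyl gives a number 0.33 log units lower from compound 2 to compound 3 (beyond the scatter), so the aryl group here can shift the number by a modest amount, which the step from compound 1 to compound 2 could not show. Against the 2-fluorophenyl of compound 1, however, the same 2-methoxyphenyl gives a number 0.11 log units lower from compound 1 to compound 3 (within the scatter), so methoxy in place of fluoro on an aromatic carbon leaves the two compounds unordered, and compound 1 cannot be separated from either compound 2 or compound 3. No measurement shown bears on the reason for the step from compound 2 to compound 3.

The step from compound 2 to compound 3 changes both the group on the phenyl ring and its number in the name, and the compounds shown do not tell these two changes apart. They also leave open how this place responds to a phenyl ring carrying an amine or a carboxylic acid, or to a longer chain between the ring and the nitrogen.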